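Swapping the arylidene ring on a thiazolidinone core

This account rests on a few compounds, and the source may have more. Where it says the series, first, only, none or still open, it means among the compounds named here.

In a functional assay on HT-29 cells (Homo sapiens) for cytotoxicity, read by MTT assay, with a stated time of 72 h (a lower number here means a stronger inhibitor, a higher number a weaker inhibitor), compound 3 `O=C1N/C(=N/c2csc(-c3ccc(Cl)cc3)c2)S/C1=C\c1ccccn1` gives 11500 nM. Among the two plain numbers measured it holds the higher one; its nearest neighbour is compound 1 `Cc1ccc(/C=C2\S/C(=N\c3csc(-c4ccc(Cl)cc4)c3)NC2=O)cc1`, which in this assay gives 6400 nM, and the gap a 1.8-fold higher number from compound 1 to compound 3 (0.25 log units; within the scatter) lies within the scatter. Compound 2 `O=C1N/C(=N/c2csc(-c3ccc(Cl)cc3)c2)S/C1=C\c1ccc(O)cc1` is reported in this assay only as a limit, > 50000 nM. The hydroxy compound thus sits apart: an at least 7.8-fold higher number from compound 1 to compound 2 (0.89 log units; beyond the scatter), and in the other direction an at least 4.3-fold lower number from compound 2 to compound 3 (0.63 log units; beyond the scatter).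

Compound 4 `O=C1N/C(=N/c2csc(-c3ccc(Cl)cc3)c2)S/C1=C\c1ccc(F)cc1` differs from compound 3 in one place: 4-fluorophenyl in place of pyridin-2-yl on a double-bonded chain carbon bound to a double-bonded ring carbon. Of the measured steps, the two ring swaps bear on it most directly. Replacing 4-methylphenyl with pyridin-2-yl changed little, while replacing 4-hydroxyphenyl with the same ring brought a sizeable gain. A 4-fluorophenyl ring carries no hydrogen-bond donor and no acceptor, so compound 4 is expected to behave like compound 1 rather than like compound 2, resting on what compound 1 gives, 6400 nM, and on what compound 3 gives, 11500 nM. The step is therefore expected to be small, a 1.6-fold lower number from compound 3 to compound 4 (0.22 log units; within the scatter), leaning towards a lower number. Compound 4 is estimated at 7000 nM, with a range from 2500 nM to 20000 nM.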

Compound 4, half-maximal inhibitory concentration: 4100 nM
Compound 4: the middle estimate sits 1.7-fold (0.23 log units) above what was measured; the measured number falls inside the stated range.
By their numbers in this assay, from the lowest: compounds 4, 1 and 3 (each within the scatter of the next, the first and the last beyond it). At a limit, above all of these: compound 2.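

In this assay, going by these compounds alone, a 2.8-fold lower number from compound 3 to compound 4 (0.45 log units; beyond the scatter) is the only step between plain numbers that lies beyond the scatter, which shows that the swap of pyridin-2-yl for 4-fluorophenyl on this double-bonded chain carbon can be told apart, whereas the earlier step between plain numbers at this place could not. That separation has limits: a 1.6-fold lower number from compound 1 to compound 4 (0.19 log units; within the scatter) stays within the scatter, so fluoro and methyl on the aromatic carbon cannot be ranked, and compound 1 lies within the scatter of both compound 3 and compound 4. The gap to the hydroxy compound now reaches an at least 12-fold lower number from compound 2 to compound 4 (1.08 log units; beyond the scatter), but this is only a bound, since compound 2 stands at a limit: the limit of > 50000 nM in this assay, at which 1 of the 4 values shown sits.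

The compounds shown leave open whether a 4-aminophenyl or 4-carboxyphenyl ring at this place would track the hydroxy compound or the fluoro and methyl compounds. They also leave open whether 4-methoxyphenyl, with its hydroxy hydrogen replaced by a methyl group, would stay close to compound 1 and compound 4, and whether pyridin-3-yl or pyridin-4-yl would differ from pyridin-2-yl.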